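The compounds below may be only part of what the source reports. "The series", "measured", "known", "first", "only" and "open" are said of these compounds alone.

Three compounds have been measured in a functional assay on HeLa cells (Homo sapiens) for cytotoxicity, read by cell counting, with a stated time of 48 h; a higher number here means that more compound is needed for the effect, a lower number that less compound is needed:

compound 1, `CCCCCCCC/C=C\CCCCCCCC(=O)OC[C@H]1O[C@@H](n2ccc(N)nc2=O)[C@@H](O)[C@@H]1OC(=O)CCCCCCC/C=C\CCCCCCCC`: 1.1 ug/mL
compound 2, `CCCCCCCCCCCCCCCCCC(=O)O[C@H]1[C@H](O)[C@H](n2ccc(N)nc2=O)O[C@@H]1CO`: 0.13 ug/mL
compound 3, `CCCCCCCCCC(=O)OC[C@H]1O[C@@H](n2ccc(N)nc2=O)[C@@H](O)[C@@H]1O`: 0.1 ug/mL

Compound 2 has the second highest of these three numbers. Its nearest neighbour is compound 3, whose value lies within the usual scatter of compound 2, so the two cannot be told apart; its furthest is compound 1, whose higher number lies beyond the scatter, meaning more of compound 1 is needed than of compound 2.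

Compound 4, `CCCCCCCCC(=O)O[C@H]1[C@H](O)[C@H](n2ccc(N)nc2=O)O[C@@H]1CO`, has not yet been measured. It differs from compound 2 in one place: hydrogen in place of nonyl on a saturated chain carbon, eight bonds along the chain from a carbonyl carbon. Going by the values given here, no measured pair shows this change on its own, so the step can only be judged indirectly. Compound 3 also carries a far shorter acyl chain than compound 2, at another place on the shared core, and its value is within the scatter of compound 2. On that basis the step of a 2.3-fold higher number from compound 2 to compound 4 (0.36 log units; beyond the scatter) is expected to be small, with a slight lean toward a higher number. Compound 4 is therefore estimated at 0.3 ug/mL, within a range from 0.08 ug/mL to 1.2 ug/mL.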

Compound 4, concentration for half-maximal effect: 0.05 ug/mL
Compound 4: middle estimate off by 6.0-fold (0.78 log units), on the high side; measured number outside the range, below it.
By their numbers in this assay, from the lowest: compounds 4, 3 and 2 (each within the scatter of the next, the first and the last beyond it); then compound 1.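

In this assay, hydrogen in place of nonyl on a saturated chain carbon, eight bonds along the chain from a carbonyl carbon, gives a 2.6-fold lower number from compound 2 to compound 4 (0.41 log units; beyond the scatter). Going by these compounds alone, this is the first direct reading of a change at this position, and it shows that the nonyl part of the chain is not needed for the effect in this assay: the shorter compound needs less, not more. Nothing available explains this difference.

With one pair, the compounds shown cannot tell whether the number falls steadily as this chain shortens or whether an intermediate chain length gives the lowest number. From the compounds shown here alone, it also remains open how a much shorter chain, or an amine or a carboxylic acid in place of nonyl, would compare with hydrogen.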